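Removing a Bromo Group on Two Related Cores

The source may report more compounds than this note shows. Statements on the series, on what has been measured and on what is new or still open speak of the compounds shown alone.

Measured compounds:
compound 1, `O=C1C(=O)N(CN2CCN(c3ccnc4cc(Cl)ccc34)CC2)c2cccc(Br)c21`, 15100 nM
compound 2, `O=C1C(=O)N(CN2CCN(c3ccnc4cc(Cl)ccc34)CC2)c2ccccc21`, 48300 nM
compound 3, `NC(=S)N/N=C1/C(=O)N(CN2CCN(c3ccnc4cc(C(F)(F)F)ccc34)CC2)c2cc(Br)ccc21`, 35500 nM

In a functional assay on MCF7 cells (Homo sapiens) for cytotoxicity, read by sulforhodamine B assay, with a stated time of 48 h (a higher number here means a weaker inhibitor of growth, a lower number a stronger inhibitor of growth), compound 1 gives 15100 nM and compound 2 gives 48300 nM. The two differ in a single place, (hydrogen in place of bromo on an aromatic carbon), and that change brought a 3.2-fold higher number from compound 1 to compound 2 (0.50 log units; beyond the scatter). Compound 3 carries the same bromo group on another core; the difference between the two cores is not broken down here. In this assay compound 3 gives 35500 nM, close to compound 2 and a higher number than compound 1.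

Compound 4, `NC(=S)N/N=C1/C(=O)N(CN2CCN(c3ccnc4cc(C(F)(F)F)ccc34)CC2)c2ccccc21`, has not been measured. It differs from compound 3 by hydrogen in place of bromo on an aromatic carbon. This is the same kind of change as that from compound 1 to compound 2, but the surroundings differ: in compound 1 the bromo stands ortho to a fused ring and meta to a fused ring, whereas in compound 3 it stands meta to a fused ring and para to a fused ring. Because the earlier step was a 3.2-fold higher number from compound 1 to compound 2 (0.50 log units; beyond the scatter), a step of a 2.4-fold higher number from compound 3 to compound 4 (0.38 log units; beyond the scatter) is expected here, with wider uncertainty since the place is not identical. Compound 4 is therefore estimated at 85000 nM, with a range from 30000 nM to 250000 nM.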

Compound 4, concentration for 50% growth inhibition: 13900 nM
For compound 4 the middle estimate is 6.1-fold (0.79 log units) above the measured one; the measured number lies below the stated range.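

In this assay, taking the bromo group off the core of compound 3 brought a 2.6-fold lower number from compound 3 to compound 4 (0.41 log units; beyond the scatter), so the same change ran in opposite directions on the two cores: the same change on two cores in this assay, a 3.2-fold higher number (0.50 log units; beyond the scatter) from compound 1 to compound 2 and a 2.6-fold lower number (0.41 log units; beyond the scatter) from compound 3 to compound 4, 8.2-fold (0.91 log units) apart, beyond the scatter of two such steps For this series, then, the step seen on one core could not be carried over to the other, not even in its direction. Among these compounds, what the comparison does not show is the source of the reversal, since the two pairs differ at once in the place of the bromo group and in other parts of the core, and two pairs set no rule for other compounds.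

From the compounds shown here alone, it remains open whether the reversal follows the place of the bromo group or some other difference between the cores, which a pair with the bromo group moved on a single core could separate. Also open, going by these compounds, is whether a methoxy group or a nitrile at these places would follow the same opposite course on the two cores.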